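The source may report more compounds than this note shows. Statements on the series, on what has been measured and on what is new or still open speak of the compounds shown alone.

Compound 1 `COc1cc(OC)cc(-c2ccc(-c3ccc(C(=N)N)c(F)c3)s2)c1`: 198 nM
Compound 2 `N=C(N)c1ccc(-c2ccc(-c3ccc(Cl)cc3)s2)cc1F`: 203 nM
Compound 3 `N=C(N)c1ccc(-c2ccc(-c3ccc(Cl)cc3)s2)cc1`: 172 nM

These three compounds were tested in a functional assay on U-251 cells (Homo sapiens) for inhibition, read by sulforhodamine B assay, with a stated time of 48 h; on this read-out higher numbers stand for weaker inhibition of growth and lower numbers for stronger inhibition of growth. Their three numbers lie close together; the widest gap among them is within the usual scatter, so no order among them can be read from these data.

Compound 2 and compound 3 differ in one place only: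

hydrogen in place of fluoro on an aromatic carbon

This change gave a 1.2-fold lower number from compound 2 to compound 3 (0.07 log units; within the scatter).

Compound 1 and compound 2 share the same kind of change in structure elsewhere, but the difference between the two cores is not broken down here.

Compound 4 `COc1cc(OC)cc(-c2ccc(-c3ccc(C(=N)N)cc3)s2)c1` has not yet been measured in this assay. It differs from compound 1 in the same way:

hydrogen in place of fluoro on an aromatic carbon

The surroundings of the place are described in the same words for both pairs, so this is the same change made on the core of compound 1 rather than on the core of compound 2.

Within the data shown here, because the only measured example of this change is a 1.2-fold lower number from compound 2 to compound 3 (0.07 log units; within the scatter), the step is expected to be small. The expected step from compound 1 to compound 4 is estimated as a 1.2-fold lower number from compound 1 to compound 4 (0.07 log units; within the scatter). Compound 4 is therefore expected to give about 170 nM in this assay, with a likely range from 90 nM to 350 nM.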

Compound 4, concentration for 50% growth inhibition: 1670 nM
The estimate for compound 4 lay 9.8-fold (0.99 log units) below the measured number; the whole stated range lies below it.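

On the core of compound 1, hydrogen in place of fluoro on an aromatic carbon gave an 8.4-fold higher number from compound 1 to compound 4 (0.93 log units; beyond the scatter) in this assay, so on this core the loss of the fluoro goes with clearly weaker inhibition of growth. The result of this change on one core therefore did not carry over to the other, and the two steps differ by more than repeated measurements would explain: the same change on two cores in this assay, a 1.2-fold lower number (0.07 log units; within the scatter) from compound 2 to compound 3 and an 8.4-fold higher number (0.93 log units; beyond the scatter) from compound 1 to compound 4, 10-fold (1.00 log units) apart, beyond the scatter of two such steps. Among these compounds, this shows that, in this series, the size of the step depends on the core that carries the change, but it rests on only two pairs, gives no reason for the difference and supports no general rule for other cores.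

The compounds shown leave open which part of the core of compound 1 sets it apart from the core of compound 2, a question that cores bearing a single methoxy group or a bromo could help to narrow down. They also leave open whether a chloro or a methyl at the place of the fluoro would follow the fluoro compounds or the hydrogen compounds on each core.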